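The source may report more compounds than this note shows. Statements on the series, on what has been measured and on what is new or still open speak of the compounds shown alone.

Of the compounds shown here, three built on one shared core have been tested in a functional assay on SF-539 cells (Homo sapiens) for antiproliferative activity, with a stated time of 48 h; on this read-out lower numbers stand for stronger inhibition of growth and higher numbers for weaker inhibition of growth. Compound 1 `Cc1cc(O)c(C2=NN(c3ccc(S(N)(=O)=O)cc3)C(c3ccccc3O)C2)cc1Cl` gives 1600 nM. Compound 2 `Cc1cc(O)c(C2=NN(c3ccc(S(N)(=O)=O)cc3)C(c3ccccc3Cl)C2)cc1Cl` carries chloro in place of hydroxy on an aromatic carbon, and the change is a 1.1-fold higher number from compound 1 to compound 2 (0.05 log units; within the scatter); compound 2 gives 1790 nM. Compound 3 `Cc1cc(O)c(C2=NN(c3ccc(S(N)(=O)=O)cc3)C(/C=C/c3ccccc3)C2)cc1Cl` carries a 2-phenylethenyl group on a saturated ring carbon of the core and gives 2980 nM. Where compound 3 stands is told by two steps, a 1.9-fold higher number from compound 1 to compound 3 (0.27 log units; within the scatter) and a 1.7-fold higher number from compound 2 to compound 3 (0.22 log units; within the scatter), so its number cannot be told apart from the other two with confidence.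

Compound 4 `COc1ccc(C2CC(c3cc(Cl)c(C)cc3O)=NN2c2ccc(S(N)(=O)=O)cc2)cc1OC` has not yet been measured. It differs from compound 3 in one place: 3,4-dimethoxyphenyl in place of 2-phenylethenyl on a saturated ring carbon. The two steps that bear on this exchange are those that swapped the group on the same saturated ring carbon, namely the move to compound 3 from compound 1 and from compound 2, each of which stayed within the scatter. Putting a six-membered aromatic ring back onto that carbon is therefore expected to give a step of about a 1.5-fold lower number from compound 3 to compound 4 (0.17 log units; within the scatter), toward a somewhat lower number but not clearly beyond the scatter. Compound 4 is estimated at 2000 nM, with a range from 1000 nM to 4000 nM.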

Compound 4, concentration for 50% growth inhibition: 2100 nM
For compound 4 the middle estimate is 1.1-fold (0.02 log units) below the measured one, within the range that was stated.
By their numbers in this assay, from the lowest: compounds 1, 2, 4 and 3 (each within the scatter of the next).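

In this assay, the saturated ring carbon next to the ring nitrogen now carries 3,4-dimethoxyphenyl, which has 10 heavy atoms and 2 hydrogen-bond acceptors, whereas the 2-phenylethenyl it replaces has 8 heavy atoms and no acceptors. This exchange gives only a small step (a 1.4-fold lower number from compound 3 to compound 4 (0.15 log units; within the scatter)), and the comparisons with the two substituted phenyl groups are just as small (a 1.2-fold higher number from compound 2 to compound 4 (0.07 log units; within the scatter)) and (a 1.3-fold higher number from compound 1 to compound 4 (0.12 log units; within the scatter)), so all four groups on this carbon give numbers that cannot be told apart with confidence. Nothing available explains this result or shows what lies behind these small steps.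

Every group shown on this carbon contains a six-membered aromatic ring, so it remains open whether an amine, a carboxylic acid or a longer alkyl chain there would give a number in the same range. On these data alone, the 4-sulfamoylphenyl and 5-chloro-2-hydroxy-4-methylphenyl groups are the same in all four compounds, so the effect of changing either one also remains open.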